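Moving a Fluorine on Two Hydroxyphenyl-Bearing Cores

The source may report more compounds than this note shows. Statements on the series, on what has been measured and on what is new or still open speak of the compounds shown alone.

Compound 1 `Oc1ccc(-c2cc(-c3cccc(F)c3)cc(-c3ccccc3O)n2)cc1` and compound 2 `Oc1ccc(-c2cc(-c3ccc(F)cc3)cc(-c3ccccc3O)n2)cc1` share one core, while compound 3 `Oc1cccc(-c2cc(-c3cccc(F)c3)cc(-c3cccc(O)c3)n2)c1` and the unmeasured compound 4 `Oc1cccc(-c2cc(-c3ccc(F)cc3)cc(-c3cccc(O)c3)n2)c1` share another; the difference between the two cores is not broken down here.

In a functional assay on DU-145 cells (Homo sapiens) for inhibition (a lower number here means a stronger inhibitor, a higher number a weaker inhibitor), compound 1 reaches only a limit of the assay, > 50000 nM. Compound 2 likewise reaches only a limit in this assay, > 50000 nM. The change between them, (4-fluorophenyl in place of 3-fluorophenyl on an aromatic carbon), therefore gives a step that the two limits leave unreadable from compound 1 to compound 2, since both ends sit at the limit of > 50000 nM in this assay, at which 2 of the 3 values shown sit. Among the measured compounds shown here, compound 3 is the one compound with a number in this assay, 23800 nM.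

For the measured compounds named here, compound 4 arises from compound 3 by 4-fluorophenyl in place of 3-fluorophenyl on an aromatic carbon, a change of the same kind as the one from compound 1 to compound 2, though the surroundings differ: there the place was meta to a 2-hydroxyphenyl group and meta to a 4-hydroxyphenyl group, here it is meta to two 3-hydroxyphenyl groups. The measured pair leaves the size of this kind of step unreadable, so the expectation for compound 4 rests chiefly on compound 3 and its 23800 nM, with a wide margin. The step from compound 3 to compound 4 is expected to be about a 1.3-fold higher number from compound 3 to compound 4 (0.10 log units; within the scatter), and compound 4 is estimated at 30000 nM, between 8000 nM and 100000 nM.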

Compound 4, half-maximal inhibitory concentration: 7120 nM
Compound 4: the middle estimate sits 4.2-fold (0.62 log units) above what was measured, and the stated range ends above it.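

With two 3-hydroxyphenyl groups on the core, 4-fluorophenyl in place of 3-fluorophenyl gives, in this assay, a 3.3-fold lower number from compound 3 to compound 4 (0.52 log units; beyond the scatter), a modest step that lies beyond the scatter. This is the only readable step of this kind, and the same change on the core of compound 1 cannot be sized, because compound 1 and compound 2 both stand at a limit of the assay and not at a number: the limit of > 50000 nM in this assay, at which 2 of the 4 values shown sit.

The series therefore shows that the fluorine's place can matter on one core, but it does not show whether the lower number carries over to the other core, where the step could be of similar size, smaller or absent.

The compounds shown leave open whether a core carrying the 4-fluorophenyl group keeps this gain when another group replaces the fluorine, such as chlorine, a methoxy group or an amine. They also leave open what a carboxylic acid in place of either hydroxyl would do on the core of compound 4.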